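Methoxy for Bromo on Two Related Cores

The compounds below may be only part of what the source reports. "The series", "measured", "known", "first", "only" and "open" are said of these compounds alone.

Compound 1 `CCOC(=O)Cc1nc(N)n(C(=O)c2ccc(Br)cc2)n1` gives 64.1% in a functional assay on the whole organism (strain albino) for inhibition, with Rattus norvegicus as the target, read by paw edema, with stated times of 30 min and 3 h, at a dose of 5 mg/kg by the oral route; a higher number here means more inhibition at the dose given (going by the name of the read-out), a lower number less inhibition. Compound 2 `CCOC(=O)Cc1nc(N)n(C(=O)c2ccc(OC)cc2)n1` carries a methoxy where compound 1 carries a bromo, the change being (methoxy in place of bromo on an aromatic carbon), and in this assay compound 2 gives 60%; the step is a number 4.1 percentage points lower from compound 1 to compound 2 (within the scatter). Compound 3 `CCOC(=O)Cc1n[nH]c(NC(=O)c2ccc(Br)cc2)n1` has the same atoms as compound 1, joined differently; the difference between the two cores is not broken down here. In this assay compound 3 gives 58.8%, a value that lies within the scatter of both compound 1 and compound 2. Compound 4 `CCOC(=O)Cc1n[nH]c(NC(=O)c2ccc(OC)cc2)n1` has not yet been measured. It stands to compound 3 as compound 2 stands to compound 1: the change is methoxy in place of bromo on an aromatic carbon, the same change as before, and among the compounds shown it occurs twice. For compound 4 the expected step is a number 3.8 percentage points lower from compound 3 to compound 4 (within the scatter), because the same change on the other core gave a number 4.1 percentage points lower from compound 1 to compound 2 (within the scatter). Compound 4 is therefore estimated at 55% in this assay, with a likely range from 42% to 67%.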

Compound 4, a percentage reported as inhibition, in the whole organism at one dose (the size of the read-out at that dose, not a potency): 56%
Estimate against measurement, compound 4: 1 percentage points below; the range from low to high includes it.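

In this assay the new step is a number 2.8 percentage points lower from compound 3 to compound 4 (within the scatter), for methoxy in place of bromo on the second core, and it can be set beside the step for the same change on the first core: the same change on two cores in this assay, a number 4.1 percentage points lower (within the scatter) from compound 1 to compound 2 and a number 2.8 percentage points lower (within the scatter) from compound 3 to compound 4, 1.3 percentage points apart, within the scatter of two such steps. The change thus behaved alike on the two cores, as neither step stands clear of the scatter and the two steps do not differ from each other. This does not show that the change has any real effect on inhibition in either core, and two small steps cannot show how it would carry over to further cores.

The compounds shown leave open whether another group on the same aromatic carbon, such as an amine or a nitrile, would give a step beyond the scatter on either core. They also leave open what would follow if the ethyl ester gave way to a carboxylic acid or a longer chain.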